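Ethoxycarbonyl to Acetyl: What to Expect for Compound 3

The source may report more compounds than this note shows. Statements on the series, on what has been measured and on what is new or still open speak of the compounds shown alone.

Of the compounds shown here, two have been measured so far. Compound 1 `CCOC(=O)/C=C1/C(=O)N2[C@@H]1SC(C)(C)[C@@H]2C(=O)OC(c1ccccc1)c1ccccc1` gives 15000 nM in a functional assay on NCI-H1299 cells (Homo sapiens) for cytotoxicity, read by MTT assay, with a stated time of 48 h; on this read-out lower numbers stand for stronger inhibition and higher numbers for weaker inhibition. Compound 2 `CC1(C)[C@H](C(=O)OC(c2ccccc2)c2ccccc2)N2C(=O)/C(=C/C(=O)c3ccccc3)[C@H]2S1(=O)=O` gives 50100 nM in this assay. Compound 1 thus has the lower of the two numbers, and compound 2 stands at a higher number, beyond the usual scatter, so compound 1 is the stronger inhibitor of the pair.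

Compound 3 `CC(=O)/C=C1/C(=O)N2[C@@H]1SC(C)(C)[C@@H]2C(=O)OC(c1ccccc1)c1ccccc1` has not yet been measured. It differs from compound 1 in one place: methyl in place of ethoxy on a carbonyl carbon, which, cut one bond further out, reads ethoxycarbonyl to acetyl. Within the data shown here, no measured pair shows this particular change, so the expectation rests on compound 1 alone. The step of a 1.2-fold higher number from compound 1 to compound 3 (0.08 log units; within the scatter) is expected to be small and within the usual scatter. Compound 3 is therefore estimated at 18000 nM, with a range from 6000 nM to 55000 nM.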

Compound 3, half-maximal inhibitory concentration: 24200 nM
The estimate for compound 3 lay 1.3-fold (0.13 log units) below the measured number; the range from low to high includes it.
By their numbers in this assay, from the lowest: compounds 1 and 3 (each within the scatter of the next); then compound 2.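

In this assay, putting methyl in place of ethoxy on a carbonyl carbon gives a 1.6-fold higher number from compound 1 to compound 3 (0.21 log units; within the scatter). Among these compounds, this is the first direct reading of a change at this position, and it shows that ethoxycarbonyl can give way to acetyl on the core of compound 1 with no difference that stands out from repeat measurements, so the ethoxy group is not needed to keep the number in this range. Nothing measured here bears on what lies behind this result.

Still open, from the compounds shown here alone, is whether a group of another kind on this carbonyl carbon, such as an amine, which would make an amide, a free carboxylic acid or a longer chain like butoxy, would also stay within the scatter of compound 1. This single pair also cannot say whether the same swap would behave alike on a different core.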